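Adding a Second Methoxy Group to Compound 1

The source may report more compounds than this note shows. Statements on the series, on what has been measured and on what is new or still open speak of the compounds shown alone.

Measured compounds:
compound 1 `COc1cccc(/C=C/C(=O)c2ccc[nH]2)c1`: 6200 nM
compound 2 `O=C(/C=C/c1ccc(OC(F)(F)F)cc1)c1ccc[nH]1`: > 20000 nM

In an assay for inhibition of cytochrome P450 1A1 (Homo sapiens), read by fluorescence, using microsomes, with a stated time of 10 min (on this read-out lower numbers stand for stronger inhibition and higher numbers for weaker inhibition), compound 1 gives 6200 nM, the only actual number among the two results shown. For compound 2 the assay reports a limit rather than a number, > 20000 nM. This is the limit of > 20000 nM in this assay, at which 1 of the 2 values shown sits. Compound 3 `COc1cccc(/C=C/C(=O)c2ccc[nH]2)c1OC` is the unmeasured partner of compound 1, and it differs from it by methoxy in place of hydrogen on an aromatic carbon. No measured pair in this set shares this change, so nothing shown fixes its size or direction. The account therefore expects a small step towards weaker inhibition, a 1.5-fold higher number from compound 1 to compound 3 (0.16 log units; within the scatter), which may well lie within the usual scatter of this assay. Compound 3 is estimated at 9000 nM, with a range from 3000 nM to 25000 nM, and some chance that only a limit is returned.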

Compound 3, half-maximal inhibitory concentration: 5200 nM
Estimate against measurement, compound 3: 1.7-fold (0.24 log units) above, and the stated range covers the measured number.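

For the compounds shown here, the change from hydrogen to methoxy at this place, ortho to a methoxy group and to a group of 9 heavy atoms, gives a 1.2-fold lower number from compound 1 to compound 3 (0.08 log units; within the scatter) in this assay and is the first reading of this change in the set. Compound 1 and compound 3 therefore read alike, and this aromatic carbon accepts a methoxy group with no shift that can be told apart from the scatter of the assay. Nothing shown bears on why the two compounds read alike.

A single pair cannot show whether every group at this place would behave the same way. Going by these compounds, a hydroxyl group, a fluorine atom, an amine or a longer chain such as ethoxy in place of the hydrogen could give a different reading, and the same change elsewhere on the shared core remains unknown.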